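The source may report more compounds than this note shows. Statements on the series, on what has been measured and on what is new or still open speak of the compounds shown alone.

Measured so far in a physicochemical assay, read by spectrophotometry, with a stated time of 60 min, tested at 100 uM; a lower number here means less inhibition, a higher number more inhibition at the concentration tested (going by the name of the read-out):

compound 1, `COc1ccc(-c2c(C)c3cc(Br)ccc3o/c2=N/Nc2ccccc2)cc1OC`: 86%
compound 2, `COc1ccc(-c2ccc3oc(=O)c(-c4ccc(OC)c(OC)c4)c(C)c3c2)cc1`: 7%

Compound 2 stands lowest of the two numbers in this assay. Its nearest neighbour is compound 1, which sits higher by a gap that is beyond the usual scatter. Among the measured compounds shown here, the two measured compounds differ from each other in more than one place, so no single step between them can be read off; only the two values themselves are known.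

The step followed here goes from compound 2 to compound 3, `COc1ccc(-c2c(C)c3cc(-c4ccc(C=O)cc4)ccc3oc2=O)cc1OC`. The change is formyl in place of methoxy on an aromatic carbon. Cut one bond further out, it reads as 4-methoxyphenyl to 4-formylphenyl, on an aromatic carbon para to a large group. For the measured compounds named here, nothing among the measured compounds shows what this exchange does in this assay.

Going by the values given here, with no measured step as guide, the expected change for a number 5 percentage points higher from compound 2 to compound 3 (within the scatter) is small, in either direction or none beyond the scatter, since compound 2 gives 7% and leaves little room downward. Compound 3 is estimated at 12%, with a range from 0% to 35%.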

Compound 3, a percentage reported as inhibition, at one concentration (the size of the read-out at that concentration, not a potency): 68%
Estimate against measurement, compound 3: 56 percentage points below, and the stated range ends below it.
By their numbers in this assay, from the lowest: compound 2; then compound 3; then compound 1.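

The series now has its first single-place step in this assay, where formyl in place of methoxy on an aromatic carbon, para to a large group, gives a number 61 percentage points higher from compound 2 to compound 3 (beyond the scatter) and no longer leaves this position without a reading. With the rest of the structure unchanged, this one exchange of 4-methoxyphenyl to 4-formylphenyl takes compound 3 to 68%, even though the two groups match in their count of heavy atoms and hydrogen-bond acceptors and differ in the double bond that formyl brings outside the aromatic rings. No measurement shown bears on what lies behind this step.

From the compounds shown here alone, whether the read-out follows the formyl group specifically remains open, since a hydroxymethyl group, a carboxylic acid or an amine on the same aromatic carbon would each test that reading in a way a single exchange cannot. Among the compounds shown here, also open is whether the same exchange gives a step of similar size on any other core, as this one pair is the only evidence for it.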